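Shortening a Branched Side Chain: Isobutyl to Isopropyl

The compounds below may be only part of what the source reports. "The series", "measured", "known", "first", "only" and "open" are said of these compounds alone.

Measured so far:
Compound 1 `CC(=O)c1ccc(NC(=O)C(C(C)C)N(C(=O)c2ccccc2)S(=O)(=O)c2ccc([N+](=O)[O-])cc2)cc1` gives 29.8% in a functional assay for inhibition, read by spectrophotometry, with a stated time of 20 min, tested at 1 mg/mL; a higher number here means a stronger effect of the compound at the concentration tested, a lower number a weaker effect.
Compound 2 `CC(=O)c1ccc(NC(=O)CN(C(=O)c2ccccc2)S(=O)(=O)c2ccccc2)cc1` gives 40.5%.
Compound 3 `CC(=O)c1ccc(NC(=O)C(CC(C)C)N(C(=O)c2ccccc2)S(=O)(=O)c2ccccc2)cc1` gives 27.7%.

Compound 3 stands lowest of the three numbers. Its nearest neighbour is compound 1, which lies within the scatter of it, while compound 2 lies beyond the scatter above it.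

Compound 4 `CC(=O)c1ccc(NC(=O)C(C(C)C)N(C(=O)c2ccccc2)S(=O)(=O)c2ccccc2)cc1` differs from compound 3 in one place: isopropyl in place of isobutyl on a saturated chain carbon bound to an amide-type nitrogen and a carbonyl carbon. Within the data shown here, only one measured step touches this place, namely a number 12.8 percentage points lower from compound 2 to compound 3 (beyond the scatter), where hydrogen was replaced by isobutyl. Isopropyl is smaller than isobutyl, so a number somewhere between compound 3 and compound 2 seems plausible, but most of that gap may not be recovered. Compound 1 also carries isopropyl at this place, though it differs from compound 4 elsewhere, and compound 1 gives 29.8%, close to compound 3.

Compound 4 is therefore expected to give about 31%, in a range from 21% to 41%. The expected change is a number 3.3 percentage points higher from compound 3 to compound 4 (within the scatter), within the scatter.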

Compound 4, a percentage reported as inhibition, at one concentration (the size of the read-out at that concentration, not a potency): 32.1%
For compound 4 the middle estimate is 1.1 percentage points below the measured one, and the stated range covers the measured number.
By their numbers in this assay, from the lowest: compounds 3, 1, 4 and 2 (each within the scatter of the next, the first and the last beyond it).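

Shortening isobutyl to isopropyl on a saturated chain carbon bound to an amide-type nitrogen and a carbonyl carbon gives a number 4.4 percentage points higher from compound 3 to compound 4 (within the scatter) in this assay, so these two branched groups cannot be told apart here. Measured against hydrogen, isopropyl gives a number 8.4 percentage points lower from compound 2 to compound 4 (within the scatter), whereas isobutyl gives a number 12.8 percentage points lower from compound 2 to compound 3 (beyond the scatter), so only isobutyl is clearly separated from hydrogen, even though it is not clearly separated from isopropyl. Hydrogen in place of nitro on an aromatic carbon gives a number 2.3 percentage points higher from compound 1 to compound 4 (within the scatter) and so makes no clear difference in this pair, and no evidence is available to explain any of these results.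

On these data alone, it remains open how a longer chain, a phenyl ring or an amine would behave on the saturated chain carbon. As far as these compounds go, it is also open whether nitro would make as little difference with hydrogen or isobutyl on that carbon.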